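Aryl ester series: methoxy to methyl on the benzoate

A few compounds are considered here, and "the series" means these few. Any claim that something is new, unique, unknown or untested is made for them only; others in the source may bear on it.

Two esters of the shared core have been run in a functional assay on PC-3 cells (Homo sapiens) for antiproliferative activity, read by sulforhodamine B assay, with a stated time of 48 h, tested at 50 uM; a higher number here means more inhibition at the concentration tested (going by the name of the read-out), a lower number less inhibition. Compound 1 `COc1cccc(C(=O)Oc2cc3c(cc2C)[C@@H](C(C)C)CC=C3C)c1` gives 16.3% in this assay. Compound 2 `COc1cccc(C(=O)Oc2cc3c(C)ccc(C(C)C)c3cc2C)c1` gives 12.5% in this assay. Compound 1 holds the highest of the two numbers, yet the gap to compound 2 lies within the scatter, so the two read as alike, and both sit at the low end of the scale. Among the measured compounds shown here, no pair of measured compounds differs in a single place, so nothing measured so far shows how one change on the benzoate part moves the read-out.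

Compound 3 `CC1=CC[C@H](C(C)C)c2cc(C)c(OC(=O)c3cccc(C)c3)cc21` is the next member. Against compound 1 it differs as methyl in place of methoxy on an aromatic carbon. Since compound 1 sits low at 16.3% and compound 2 sits low as well, no shift beyond the scatter is expected in either direction, and the step is estimated as a number 1.3 percentage points lower from compound 1 to compound 3 (within the scatter). Compound 3 is therefore expected to give 15% in this assay, within a range from 4% to 28%.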

Compound 3, a percentage reported as inhibition, at one concentration (the size of the read-out at that concentration, not a potency): 38.6%
The estimate for compound 3 lay 23.6 percentage points below the measured number; the measured number lies above the stated range.
By their numbers in this assay, from the lowest: compounds 2 and 1 (each within the scatter of the next); then compound 3.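

Among the compounds shown here, on the benzoate ring, the change from 3-methoxyphenyl to 3-methylphenyl gives the first comparison in this assay that differs in one place only: a number 22.3 percentage points higher from compound 1 to compound 3 (beyond the scatter). This shows that the position, an aromatic carbon meta to a large group, is not indifferent to its substituent, a point that compound 1 and compound 2 could not settle, and that exchanging a methoxy, which counts a hydrogen-bond acceptor, for a methyl, which counts none, is enough to move the read-out, with compound 3 at 38.6%. No measurement at hand accounts for the step, and this single pair does not assign it to the departing methoxy or the entering methyl.

Open, as far as these compounds go, is whether the higher number belongs to methyl in particular or would also appear with a hydrogen, a chlorine, an ethyl group or an amine at the same carbon. Also open, from the compounds shown here alone, is whether the same exchange would move the read-out in the same direction on the core of compound 2, and whether the step would hold as a difference in potency rather than at one tested concentration.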